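The source may hold more compounds than are shown below. What is called first, only, known or untested is meant among the compounds shown, and "the series" means these compounds.

Measured so far:
- compound 1, `CC[C@H]1N[C@@H](CO)[C@@H](O)[C@H](O)[C@H]1O`: 8.7%
- compound 2, `CCC[C@@H]1NC[C@@H](O)[C@@H](O)[C@H](O)[C@H]1O`: 46%

In an assay on isolated protein for inhibition of alpha-galactosidase (Coffea arabica), tested at 1000 uM (on this read-out lower numbers stand for less inhibition and higher numbers for more inhibition at the one concentration tested (going by the name of the read-out)), compound 1 gives 8.7%, the lowest of the two numbers, and compound 2 gives 46%, a number beyond the scatter higher. Within the data shown here, no step between measured compounds is available.

Compound 3, `CC[C@@H]1N[C@H](CC)[C@H](O)[C@@H](O)[C@@H]1O`, is not yet measured. It differs from compound 1 as methyl in place of hydroxy on a saturated chain carbon bound to a saturated ring carbon. Among the measured compounds shown here, with no measured step to draw on, the expectation is that compound 3 stays near compound 1, the change a number 1.7 percentage points lower from compound 1 to compound 3 (within the scatter) being none beyond the scatter or a small decrease. Compound 3 is estimated at 7%, within 0% to 25%.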

Compound 3, a percentage reported as inhibition, at one concentration (the size of the read-out at that concentration, not a potency): 3.7%
Compound 3: the middle estimate sits 3.3 percentage points above what was measured, and the stated range covers the measured number.
By their numbers in this assay, from the lowest: compounds 3 and 1 (each within the scatter of the next); then compound 2.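

Replacing hydroxy with methyl on a saturated chain carbon bound to a saturated ring carbon, which turns hydroxymethyl into ethyl, gives in this assay a number 5 percentage points lower from compound 1 to compound 3 (within the scatter). This hydroxy is therefore not shown to matter to this read-out on the core of compound 1, although that core gives low numbers with either group, so a loss would have little room to show. Nothing available bears on the reason for this result. Still open, from the compounds shown here alone, is whether an amine, a carboxylic acid or a longer chain at this place would move the number beyond the scatter.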